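Lengthening the Aryl Ether from Methoxy to Ethoxy

The compounds below may be only part of what the source reports. "The series", "measured", "known", "first", "only" and "open" are said of these compounds alone.

Three compounds have been tested in a functional assay on MDA-MB-231 cells (Homo sapiens) for cytotoxicity, read by MTT assay, with a stated time of 72 h; a lower number here means that less compound is needed, a higher number that more compound is needed for the effect:
- compound 1, `CCOc1c(-c2occ(C)c2C(=O)O)ccc2c(CC)cccc12`: only a limit, > 10 ug/mL
- compound 2, `CCc1cccc2c(OC(C)=O)c(-c3occ(C)c3COC(C)=O)ccc12`: only a limit, > 10 ug/mL
- compound 3, `CCc1cccc2c(OC)c(-c3occ(C)c3COC(C)=O)ccc12`: 3.5 ug/mL

For the measured compounds named here, compound 3 thus stands alone as the only real number in this assay; the other two sit at the limit of > 10 ug/mL in this assay, at which 2 of the 3 values shown sit. Going by the values given here, the one measured step, an at least 2.8-fold lower number from compound 2 to compound 3 (0.45 log units; beyond the scatter), concerns the group on the aromatic oxygen.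

Compound 4, `CCOc1c(-c2occ(C)c2COC(C)=O)ccc2c(CC)cccc12`, differs from compound 3 by methyl in place of hydrogen on a saturated chain carbon bound to an oxygen on an aromatic ring. Among the compounds with values here, no measured step covers this change. Compound 1 also carries an ethoxy group, but it differs from compound 4 elsewhere too, so it offers no direct guide. The expected step of a 1.4-fold higher number from compound 3 to compound 4 (0.15 log units; within the scatter) is therefore small, within the usual scatter. Compound 4 is estimated at 5 ug/mL, with a range from 2 ug/mL to 12 ug/mL.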

Compound 4, concentration for half-maximal effect: 4.9 ug/mL
The estimate for compound 4 lay 1.0-fold (0.01 log units) above the measured number, within the range that was stated.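

Ethoxy in place of methoxy gives a 1.4-fold higher number from compound 3 to compound 4 (0.15 log units; within the scatter), so in this assay this position takes the added methyl and the two compounds cannot be told apart. Ethyl in place of acetyl on the oxygen gives an at least 2.0-fold lower number from compound 2 to compound 4 (0.30 log units; that floor lies within the scatter), and acetoxymethyl in place of carboxy gives an at least 2.0-fold lower number from compound 1 to compound 4 (0.30 log units; that floor lies within the scatter). Both of these steps start from a limit, not a number: the limit of > 10 ug/mL in this assay, at which 2 of the 4 values shown sit.

As far as these compounds go, whether a longer chain on this oxygen, such as propoxy, would keep the number in this range remains open. So does the effect of an amine at the end of that chain.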